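Thiosemicarbazone Aryl Swap on Colon Cancer Cell Growth

The compounds below may be only part of what the source reports. "The series", "measured", "known", "first", "only" and "open" are said of these compounds alone.

Compound 1, `CC1=CC[C@H](C(C)(C)NC(=S)NN)CC1`: > 100000 nM
Compound 2, `CC1=CC[C@H](C(C)(C)NC(=S)N/N=C/c2cccc(Cl)c2)CC1`: 53000 nM

In a functional assay on HT-29 cells (Homo sapiens) for inhibition, read by sulforhodamine B assay, with a stated time of 48 h (on this read-out higher numbers stand for weaker inhibition of growth and lower numbers for stronger inhibition of growth), compound 1 reaches only the assay limit of > 100000 nM. Among the measured compounds shown here, compound 2 gives 53000 nM in this assay, the only number among the values shown. The other value shown, that of compound 1, is a limit of the assay (the limit of > 100000 nM in this assay, at which 1 of the 2 values shown sits). Compound 3, `CC1=CC[C@H](C(C)(C)NC(=S)N/N=C/c2ccc[nH]2)CC1`, differs from compound 2 by 1H-pyrrol-2-yl in place of 3-chlorophenyl on a carbon with a double bond to nitrogen. For the measured compounds named here, no measured step covers this change, so only a guarded expectation is possible: the step is estimated as a 1.7-fold higher number from compound 2 to compound 3 (0.23 log units; within the scatter), a modest move toward weaker growth inhibition that may not clear the scatter. Compound 3 is therefore expected to give about 90000 nM in this assay, within 30000 nM to 300000 nM.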

Compound 3, concentration for total growth inhibition: > 100000 nM
Compound 3 ended at the assay's limit; the forecaster's own chance of this, stated with the estimate: 45%; at least 1.1-fold (0.04 log units) between middle value and limit.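

With 1H-pyrrol-2-yl in place of 3-chlorophenyl, this position now has its first step in this assay, an at least 1.8-fold higher number from compound 2 to compound 3 (0.27 log units; that floor lies within the scatter), so the floor alone shows no change beyond the scatter. Compound 3 gives a limit of the assay and not a number, as compound 1 does: the limit of > 100000 nM in this assay, at which 2 of the 3 values shown sit. The step from compound 1 to compound 3 cannot be read.

On these data alone, the true size of the step from 3-chlorophenyl to 1H-pyrrol-2-yl remains open. So does whether an unsubstituted phenyl or a pyridyl group at this place would give a number rather than a limit in this assay.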